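The source may hold more compounds than are shown below. What is called first, only, known or untested is meant among the compounds shown, and "the series" means these compounds.

Three compounds of the series have numbers in a functional assay on HEK293 cells for agonist activity at D(4) dopamine receptor (Homo sapiens), read by FLIPR; on this read-out higher numbers stand for an effect only at larger amounts of compound and lower numbers for an effect already at smaller amounts. Compound 1 `O=C(CN1CCC(c2cccc[n+]2[O-])CC1)Nc1cccc(Cl)c1` gives 62 nM. Compound 3 `Cc1cccc(NC(=O)CN2CCC(c3ccc(O)cc3)CC2)c1` gives 70 nM; the two numbers lie within the scatter of each other, so nothing separates them. Compound 2 `Cc1cccc(C(=O)NCN2CCC(c3ccccn3)CC2)c1` gives 9 nM, a number beyond the scatter below the other two, so compound 1 stands second highest of the three, with compound 3 nearest and compound 2 furthest. For the measured compounds named here, no step between measured compounds differing in one place is available, so no measured step sets a scale for the change at hand.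

Compound 4 `CSc1cccc(NC(=O)CN2CCC(c3cccc[n+]3[O-])CC2)c1` is not yet measured. It differs from compound 1 in one place: methylsulfanyl in place of chloro on an aromatic carbon. Going by the values given here, none of the measured compounds varies this position, so the change is judged without a reference. The step of a 1.1-fold higher number from compound 1 to compound 4 (0.05 log units; within the scatter) is expected to stay within the scatter, with no clear direction. For compound 4 the estimate is 70 nM, with a range from 25 nM to 200 nM.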

Compound 4, half-maximal effective concentration: 100 nM
Estimate against measurement, compound 4: 1.4-fold (0.15 log units) below; measured number inside the range.
By their numbers in this assay, from the lowest: compound 2; then compounds 1, 3 and 4 (each within the scatter of the next).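

In this assay, for the compounds shown here, the replacement of chloro by methylsulfanyl gives a 1.6-fold higher number from compound 1 to compound 4 (0.21 log units; within the scatter), the first reading of a change at this position on the core of compound 1. The step stays within the scatter, so this one exchange gives no sign that the group at this place matters to the number, even though methylsulfanyl brings more heavy atoms and a hydrogen-bond acceptor that chloro lacks. Nothing available accounts for the size of this step or for its direction, and the step itself cannot separate the two groups. As far as these compounds go, only these two groups are compared at this place, so the effect of a clearly different group there, such as an amine, a carboxylic acid or a longer thioether chain, remains open. Also open, from the compounds shown here alone, is whether the same exchange would stay as small on the core of compound 2.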